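This account rests on a few compounds, and the source may have more. Where it says the series, first, only, none or still open, it means among the compounds named here.

Measured compounds in a functional assay on the whole organism (strain albino) for inhibition, with Rattus norvegicus as the target, read by paw edema, with a stated time of 1 h, at a dose of 0.28 mmol/kg by the oral route; a lower number here means less inhibition, a higher number more inhibition at the dose given (going by the name of the read-out):

Compound 1, `COc1ccc(-c2nnc(SC/C(=N/O)c3ccccc3)n2-c2ccccc2)cc1`: 58%
Compound 2, `O/N=C(/CSc1nnc(-c2ccccc2)n1-c1ccccc1)c1ccccc1`: 60%
Compound 3, `CCn1c(SC/C(=N/O)c2ccccc2)nnc1-c1ccc(OC)cc1`: 69%

Compound 3 gives the highest of the three numbers. Its nearest neighbour is compound 2, whose value sits within the scatter of it, so the two cannot be ranked; the step of a number 11 percentage points higher from compound 1 to compound 3 (beyond the scatter) is the only one in the set that lies beyond the scatter, and it is modest. Compound 3 is therefore best described as at the top of the set without being separated from compound 2.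

Compound 4, `CCn1c(SC/C(=N/O)c2ccccc2)nnc1-c1ccccc1`, is not yet measured. It differs from compound 3 in one place: hydrogen in place of methoxy on an aromatic carbon. Methoxy leaves, hydrogen enters, on an aromatic carbon of a six-membered aromatic ring of carbon only, para to a large group.

For the measured compounds named here, one measured step bears on this, the same exchange made on the core carrying phenyl on the aromatic nitrogen: a number 2 percentage points higher from compound 1 to compound 2 (within the scatter). That step is within the scatter. Nothing in the measured set suggests the exchange behaves differently on the ethyl-bearing core, so no step beyond the scatter is expected in this assay in either direction.

For compound 4 the expected value in this assay is 70%, with a range from 58% to 80%. The expected step is a number 1 percentage points higher from compound 3 to compound 4 (within the scatter), taken as noise rather than change.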

Compound 4, a percentage reported as inhibition, in the whole organism at one dose (the size of the read-out at that dose, not a potency): 65%
Estimate against measurement, compound 4: 5 percentage points above, and the stated range covers the measured number.
By their numbers in this assay, from the lowest: compounds 1, 2, 4 and 3 (each within the scatter of the next, the first and the last beyond it).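

In this assay, the exchange of methoxy for hydrogen, 4-methoxyphenyl to phenyl, can now be read on the ethyl-bearing core as well, where it gives a number 4 percentage points lower from compound 3 to compound 4 (within the scatter), so on neither core does it move the number beyond the scatter, and the two readings do not separate: the same change on two cores in this assay, a number 2 percentage points higher (within the scatter) from compound 1 to compound 2 and a number 4 percentage points lower (within the scatter) from compound 3 to compound 4, 6 percentage points apart, within the scatter of two such steps.

For the compounds shown here, the exchange of phenyl for ethyl on the aromatic nitrogen can also be read a second time, on the core without methoxy, where it gives a number 5 percentage points higher from compound 2 to compound 4 (within the scatter), so the one step beyond the scatter in the set does not recur there, although the two readings of this exchange cannot be told apart: the same change on two cores in this assay, a number 11 percentage points higher (beyond the scatter) from compound 1 to compound 3 and a number 5 percentage points higher (within the scatter) from compound 2 to compound 4, 6 percentage points apart, within the scatter of two such steps.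

At this position, methoxy and hydrogen are therefore not distinguished at the single dose and time used, and the effect of ethyl in place of phenyl remains a modest result on the methoxy core alone.

The compounds shown leave open whether a chlorine atom, a dimethylamino group or a carboxylic acid in place of methoxy would give a step beyond the scatter. They also leave open what a longer chain such as butyl would give in place of ethyl on the aromatic nitrogen.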